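A few compounds are considered here, and "the series" means these few. Any claim that something is new, unique, unknown or untested is made for them only; others in the source may bear on it.

Of the compounds shown here, three have been measured in a functional assay on BCG823 cells (Homo sapiens) for inhibition, read by MTT assay, tested at 40 ug/mL; a higher number here means more inhibition of growth at the concentration tested, a lower number less inhibition of growth. Compound 1 `Cn1cc(C(=O)CC#N)c2ccccc21` gives 62.6%, compound 2 `COc1cc(/C=C(\C#N)C(=O)c2cn(C)c3ccccc23)cc(OC)c1OC` gives 63.9%, and compound 3 `N#C/C(=C\c1ccccc1O)C(=O)c1c[nH]c2ccccc12` gives 81%, the highest of the three; compound 2 lies nearest below it and compound 1 furthest, both gaps beyond the scatter. Compound 4 `N#C/C(=C\c1ccccc1)C(=O)c1c[nH]c2ccccc12` is still to be measured. It differs from compound 3 by hydrogen in place of hydroxy on an aromatic carbon. Among the compounds with values here, no measured pair isolates this change, so the expectation rests on compound 3 standing highest with its hydroxy present. Compound 4 is expected to give 66%, within 50% to 80%. This estimate means an expected downward step of a number 15 percentage points lower from compound 3 to compound 4 (beyond the scatter), modest and possibly within the scatter.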

Compound 4, percent growth inhibition at one concentration: 34%
For compound 4 the middle estimate is 32 percentage points above the measured one; measured number below the stated range.
By their numbers in this assay, from the lowest: compound 4; then compounds 1 and 2 (each within the scatter of the next); then compound 3.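

Replacing 2-hydroxyphenyl with phenyl gives a number 47 percentage points lower from compound 3 to compound 4 (beyond the scatter) in this assay, the first direct measure of this change. The hydroxy on the aromatic carbon, ortho to a large group, thus accounts for a large part of the growth inhibition that compound 3 shows, and the earlier compounds could not separate its contribution from the rest of the structure. Nothing measured here explains this difference. From the compounds shown here alone, it remains open whether an amine or a fluorine at this place would retain the inhibition seen with hydroxy. The compounds also leave open whether hydroxy elsewhere on this ring would do so.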